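This account rests on a few compounds, and the source may have more. Where it says the series, first, only, none or still open, it means among the compounds named here.

In a functional assay on HL-60 cells (Homo sapiens) for inhibition, read by MTT assay, with a stated time of 72 h (a lower number here means a stronger inhibitor, a higher number a weaker inhibitor), compound 1 `Cc1ccc(C)c(N2CCN(C(=O)c3oc(C)nc3-c3ccccc3)CC2)c1` gives 31.3 nM. Compound 2 `Cc1nc(-c2ccccc2)c(C(=O)N2CCN(c3ccc(F)cc3)CC2)o1` gives > 1000 nM, which is a limit of the assay and not a number. Compound 3 `Cc1cc(C)cc(N2CCN(C(=O)c3oc(C)nc3-c3ccccc3)CC2)c1` has 3,5-dimethylphenyl in place of 4-fluorophenyl on an amine nitrogen in a ring. Going by the values given here, one measured step bears on this change, an at least 31-fold higher number from compound 1 to compound 2 (1.50 log units; beyond the scatter), a large step at the same nitrogen. Read in reverse, it points to a large fall in this assay on leaving 4-fluorophenyl. Among the compounds with values here, the dimethylphenyl group of compound 3 is not the one in compound 1, which gives 31.3 nM, so only part of that step may carry over. A lower number and a stronger inhibitor are therefore expected, with an estimated step of an at least 12-fold lower number from compound 2 to compound 3 (1.09 log units; beyond the scatter). For compound 3 the expected value is 80 nM, with an estimated range of 15 nM to 500 nM.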

Compound 3, half-maximal inhibitory concentration: 34.5 nM
Beside the measured number, compound 3's estimate is 2.3-fold (0.37 log units) above it, within the range that was stated.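

In this assay, the two dimethylphenyl groups on this ring nitrogen read alike, with a 1.1-fold higher number from compound 1 to compound 3 (0.04 log units; within the scatter), so the arrangement of the two methyl groups in 2,5-dimethylphenyl and 3,5-dimethylphenyl does not separate these compounds. The large step seen earlier is therefore not tied to 2,5-dimethylphenyl alone, since the change from 4-fluorophenyl to 3,5-dimethylphenyl also gives an at least 28-fold lower number from compound 2 to compound 3 (1.46 log units; beyond the scatter). The value of compound 2 is a limit of the assay and not a number, so this step sets only a bound on the true size of the change: the limit of > 1000 nM in this assay, at which 1 of the 3 values shown sits.

The compounds shown leave open whether a single methyl group on the phenyl ring would be enough, and whether the weak result belongs to the fluorine or to the absence of methyl groups. Going by these compounds, how an unsubstituted phenyl, a methoxyphenyl or a pyridine ring on this nitrogen would compare also remains open.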